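This account rests on a few compounds, and the source may have more. Where it says the series, first, only, none or still open, it means among the compounds named here.

Compound 1 `COc1ccccc1Oc1ccc2c(NCCCNCc3ccco3)ccnc2c1` gives 9.28 in a physicochemical assay for acid dissociation.
Compound 2 `CCC(CC)c1ccc2c(NCCCNCc3cccc(OC)c3O)ccnc2c1` gives 9.47 in this assay.
Compound 3 `CCC(CC)c1ccc2c(NCCCNCc3cc(F)ccc3OC)ccnc2c1` gives 9.47 in this assay.

Among the three measured compounds, compound 2 stands level with compound 3, and the value of compound 1 differs from it only within the scatter of this assay, so none of the three can be set apart from the others.

Compound 4 `COc1cccc(CNCCCNc2ccnc3cc(CC(C)C)ccc23)c1O` has not yet been measured. It differs from compound 2 in one place: isobutyl in place of pentan-3-yl on an aromatic carbon

Within the data shown here, the only measured step in which a single group was exchanged is no change at the digits printed from compound 2 to compound 3 (within the scatter). That exchange sat on the chain end of the molecule, far from the core, and left the number where it was. Among the measured compounds shown here, no measured step exchanges the group on the core itself, so there is no direct precedent for the change to compound 4. Because no change at the digits printed from compound 2 to compound 3 (within the scatter) showed no movement and the exchanged groups here are both plain carbon chains without donors or acceptors, the step of no change at the digits printed from compound 2 to compound 4 (within the scatter) is expected to stay within the scatter. Compound 4 is therefore estimated at 9.47, with a range from 9.17 to 9.77.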

Compound 4, acid dissociation constant: 9.47
For compound 4 middle estimate and measured number coincide at the digits printed, and the stated range covers the measured number.
By their numbers in this assay, from the lowest: compounds 1, 2, 3 and 4 (each within the scatter of the next).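

Exchanging pentan-3-yl for isobutyl on an aromatic carbon of the shared core gives, in this assay, no change at the digits printed from compound 2 to compound 4 (within the scatter), and this is the first single exchange shown at this place on the core rather than at the chain end. Here, one branched carbon chain with 5 heavy atoms gives way to another with 4, and the read-out does not separate the two. No measurement at hand explains this result.

Both groups are plain carbon chains with no ring, so the result covers only an exchange of that kind. As far as these compounds go, whether an amine, a carboxylic acid or a phenyl ring on the same aromatic carbon would leave the number in place remains open, as does the effect of a much longer chain there.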